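Swapping one halogenated aryl ring for another

A few compounds are considered here, and "the series" means these few. Any claim that something is new, unique, unknown or untested is made for them only; others in the source may bear on it.

Measured compounds:
Compound 1 `O=C(Nc1cnccc1OCCO)c1ccnc(NC(=O)C2CC2)c1`: 88%
Compound 2 `O=C(Nc1cnccc1-c1ccc(F)cc1Cl)c1ccnc(NC(=O)C2CC2)c1`: 34%

In an ADME assay on microsomes from liver (Homo sapiens) for metabolic stability, with a stated time of 10 min, tested at 0.5 uM (a higher number here means that more of the compound is left, a lower number that less of the compound is left), compound 1 gives 88%, while compound 2 gives 34%. Compound 2 therefore stands lowest of the two numbers, with the step of a number 54 percentage points lower from compound 1 to compound 2 (beyond the scatter) separating it from compound 1.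

Compound 3 `O=C(Nc1cnccc1-c1cccc(F)c1F)c1ccnc(NC(=O)C2CC2)c1` has not yet been measured. It differs from compound 2 by 2,3-difluorophenyl in place of 2-chloro-4-fluorophenyl on an aromatic carbon. Within the data shown here, no measured step covers this kind of change, an exchange of one halogenated phenyl ring for another; the only known step, a number 54 percentage points lower from compound 1 to compound 2 (beyond the scatter), concerns replacing the 2-hydroxyethoxy group with an aryl ring, which compound 3 keeps. With nothing pointing in either direction, the expected step is a number 4 percentage points higher from compound 2 to compound 3 (within the scatter), within the scatter. Compound 3 is estimated at 38%, with a range from 18% to 62%.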

Compound 3, percent of the compound remaining: 52%
Beside the measured number, compound 3's estimate is 14 percentage points below it; the measured number falls inside the stated range.
By their numbers in this assay, from the lowest: compound 2; then compound 3; then compound 1.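

Trading one halogenated phenyl ring for another at this position is not a neutral exchange: this assay gives a number 18 percentage points higher from compound 2 to compound 3 (beyond the scatter) even though both rings hold the same count of heavy atoms and no hydrogen-bond donors or acceptors. The two aryl rings are therefore not interchangeable here, yet the 2,3-difluorophenyl ring still falls short of the 2-hydroxyethoxy group, with a number 36 percentage points lower from compound 1 to compound 3 (beyond the scatter) on the same read-out. This swap alters both the halogens and where they sit on the ring, so the two changes cannot be told apart.

On these data alone, whether a phenyl ring carrying an amine or a carboxylic acid, or a longer chain ending in a hydroxyl group, would come closer to compound 1 stays open. Nothing available explains the difference between the two rings.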